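This account rests on a few compounds, and the source may have more. Where it says the series, first, only, none or still open, it means among the compounds named here.

Of the compounds shown here, three with a shared core have been measured in a functional assay on MDA-MB-231 cells (Homo sapiens) for inhibition, read by MTT assay, with a stated time of 24 h; a higher number here means a weaker inhibitor, a lower number a stronger inhibitor. Compound 1 `C(=N/c1ccccc1)\c1cc(-c2ccccc2)no1` gives only a limit of the assay, > 100000 nM, as noted in the limit of > 100000 nM in this assay, at which 1 of the 3 values shown sits. Within the data shown here, compound 2 `FC(F)(F)c1ccc(-c2cc(/C=N/c3ccccc3)on2)cc1` gives 37400 nM, and the change an at least 2.6-fold lower number from compound 1 to compound 2 (0.42 log units; beyond the scatter) is the one measured step. Compound 3 `CCCc1cc2ccccc2nc1-c1cc(-c2ccccc2)no1` gives 47200 nM in this assay , a number that sits close to that of compound 2, within the scatter of repeated measurements.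

The next compound, compound 4 `CCCCCc1cc2ccccc2nc1-c1cc(-c2ccccc2)no1`, differs from compound 3 by ethyl in place of hydrogen on a saturated chain carbon, three bonds along the chain from an aromatic carbon. Among the measured compounds shown here, no measured step touches a chain of this kind: the single step known, from compound 1 to compound 2, swaps a group on an aromatic carbon, so it does not bear on lengthening a saturated chain. With nothing in the data pointing either way, the expected step of a 1.0-fold lower number from compound 3 to compound 4 (0.02 log units; within the scatter) is none beyond the scatter. Compound 4 is therefore estimated at 45000 nM in this assay , with a range from 15000 nM to 100000 nM.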

Compound 4, half-maximal inhibitory concentration: > 100000 nM
Compound 4 gave a limit, no number; the forecaster's own chance of this, stated with the estimate: 25%; middle value at least 2.2-fold (0.34 log units) from the limit.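

Lengthening the propyl chain of compound 3 to the pentyl chain of compound 4 gives the first measured change on a saturated chain rather than on an aromatic carbon, and in this assay it shows an at least 2.1-fold higher number from compound 3 to compound 4 (0.32 log units; beyond the scatter). So this position does not tolerate every addition: ethyl in place of hydrogen here goes with a weaker inhibitor, by a margin beyond the scatter. The result for compound 4 is a limit, not a number, so the step is known only as a minimum, and compound 4 is the second compound at that limit: the limit of > 100000 nM in this assay, at which 2 of the 4 values shown sit.

As far as these compounds go, whether a butyl chain would already weaken the compound, or whether a shorter ethyl or methyl group would strengthen it, stays open. The compounds shown also do not tell how an amine or a carboxylic acid in place of the propyl chain would read in this assay.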